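Amide substituent swap on the shared core

A few compounds are considered here, and "the series" means these few. Any claim that something is new, unique, unknown or untested is made for them only; others in the source may bear on it.

Compound 1 `CC(C)=CCCC1=CC[C@H](C(=O)NCCC(=O)O)[C@@H](c2ccccc2)C1` carries a 2-carboxyethyl group on the amide-type nitrogen of the shared core. In an assay on isolated protein for inhibition of Apoptosis regulator Bcl-2 (Homo sapiens), read by fluorescence polarization, with stated times of 5 min and 10 min (a lower number here means a stronger inhibitor, a higher number a weaker inhibitor), compound 1 reports only a limit of the assay, > 23000 nM. Compound 1 thus stands at the limit of > 23000 nM in this assay, at which 1 of the 3 values shown sits. Compound 2 `CONC(=O)[C@@H]1CC=C(CCC=C(C)C)C[C@H]1c1ccccc1` places a methoxy group on that nitrogen, and in this assay compound 2 gives 2700 nM. Compound 3 `CC(C)=CCCC1=CC[C@@H](C(=O)Nc2ccc(C(=O)O)cc2)[C@H](c2ccccc2)C1` carries a 4-carboxyphenyl group on the nitrogen; in this assay compound 3 gives 2200 nM. Within the data shown here, the one measured step, a 1.2-fold lower number from compound 2 to compound 3 (0.09 log units; within the scatter), is within the scatter, so the methoxy amide and the aryl acid amide sit alike. Compound 4 `COc1ccc(NC(=O)[C@H]2CC=C(CCC=C(C)C)C[C@@H]2c2ccccc2)cc1` is yet to be measured; its change from compound 1 is 4-methoxyphenyl in place of 2-carboxyethyl on an amide-type nitrogen. Among the measured compounds shown here, no measured step mirrors that change, so the estimate rests on the aryl amide already seen. Compound 4 is estimated at 2500 nM, with a range from 800 nM to 8000 nM, because compound 3 gives 2200 nM with its aryl amide. This estimate amounts to an expected step of an at least 9.2-fold lower number from compound 1 to compound 4 (0.96 log units; beyond the scatter).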

Compound 4, inhibition constant: > 23000 nM
Compound 4: no number, only a limit (the forecaster's own chance of this, stated with the estimate: 10%); middle value at least 9.2-fold (0.96 log units) away from the limit.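

Compound 1 and compound 4 each report only a limit in this assay, so the step between them cannot be read: the limit of > 23000 nM in this assay, at which 2 of the 4 values shown sit. The compounds shown leave open whether 4-methoxyphenyl or 2-carboxyethyl on the amide-type nitrogen gives the lower number.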